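Carrying the Fluorophenyl Exchange Over to a Second Core

The source may report more compounds than this note shows. Statements on the series, on what has been measured and on what is new or still open speak of the compounds shown alone.

Of the compounds shown here, three of a shared core have been measured in an assay on CHO cells for activation of soluble guanylate cyclase alpha1/beta1 complex (Homo sapiens), read by cGMP accumulation; a lower number here means that less compound is needed, a higher number that more compound is needed for the effect. Compound 1 `CC1(C)C(=O)Nc2nc(-n3nc(Cc4ccccc4F)c4cc(Cl)ccc43)nc(N)c21` gives 18000 nM in this assay. Compound 3 `CC1(C)C(=O)Nc2nc(-n3nc(CCC(F)(F)F)c4cc(Cl)ccc43)nc(N)c21` gives 87000 nM in this assay. Compound 2 `CC1(C)C(=O)Nc2nc(-n3nc(CCC(F)(F)F)c4ccccc43)nc(N)c21` gives 882000 nM in this assay, the highest of the three numbers.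

Two steps connect them. The step of a 4.8-fold lower number from compound 3 to compound 1 (0.68 log units; beyond the scatter) goes with the change (2-fluorophenyl in place of 2,2,2-trifluoroethyl on a saturated chain carbon bound to an aromatic carbon). The step of a 10-fold lower number from compound 2 to compound 3 (1.01 log units; beyond the scatter) goes with the difference between the two cores, which reads (hydrogen in place of chloro on an aromatic carbon).

Compound 4 `CC1(C)C(=O)Nc2nc(-n3nc(Cc4ccccc4F)c4ccccc43)nc(N)c21` has not yet been measured in this assay. It differs from compound 2 by 2-fluorophenyl in place of 2,2,2-trifluoroethyl on a saturated chain carbon bound to an aromatic carbon. This is the same change as that from compound 3 to compound 1, made on the other core, and the place of the change is described in identical words in both cases.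

The step is expected to be a 4.9-fold lower number from compound 2 to compound 4 (0.69 log units; beyond the scatter), resting on the observation that the same exchange gave a 4.8-fold lower number from compound 3 to compound 1 (0.68 log units; beyond the scatter). Compound 4 is thus estimated at 180000 nM, with an expected range from 60000 nM to 500000 nM in this assay.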

Compound 4, half-maximal effective concentration: 3000 nM
For compound 4 the middle estimate is 60-fold (1.78 log units) above the measured one; the measured number lies below the stated range.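

In this assay the exchange of 2,2,2-trifluoroethyl for 2-fluorophenyl again goes with a lower number on the core without chloro, a 290-fold lower number from compound 2 to compound 4 (2.47 log units; beyond the scatter), so its direction carries over from one core to the other but its size does not: the same change on two cores in this assay, a 4.8-fold lower number (0.68 log units; beyond the scatter) from compound 3 to compound 1 and a 290-fold lower number (2.47 log units; beyond the scatter) from compound 2 to compound 4, 61-fold (1.78 log units) apart, beyond the scatter of two such steps

The chloro change behaves differently in the two pairs, since with the 2-fluorophenyl group in place, hydrogen in place of chloro gives a 6.0-fold lower number from compound 1 to compound 4 (0.78 log units; beyond the scatter), which is the opposite direction to the pair carrying 2,2,2-trifluoroethyl: the same change on two cores in this assay, a 10-fold lower number (1.01 log units; beyond the scatter) from compound 2 to compound 3 and a 6.0-fold higher number (0.78 log units; beyond the scatter) from compound 4 to compound 1, 61-fold (1.78 log units) apart, beyond the scatter of two such steps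

These four compounds therefore show that the two changes do not add up independently in this series, but they do not show why, and a single set of four cannot show how far this holds for other groups or cores.

As far as these compounds go, it remains open whether an unsubstituted phenyl or a longer chain in place of the 2-fluorophenyl group would follow compound 4 or compound 1. From the compounds shown here alone, it is equally open whether a bromo or methoxy group in place of chloro would reverse the step in the same way.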